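A few compounds are considered here, and "the series" means these few. Any claim that something is new, unique, unknown or untested is made for them only; others in the source may bear on it.

Within the data shown here, compound 3 `COc1ccc(OCC(=O)NNC(=S)NCCCCC2CCCCC2)cc1` is one of three compounds measured in an assay on isolated protein for inhibition of A disintegrin and metalloproteinase with thrombospondin motifs 5 (Homo sapiens), read by spectrophotometry, with stated times of 10 min and 3 h; on this read-out lower numbers stand for stronger inhibition and higher numbers for weaker inhibition. In this assay compound 1 `O=C(COc1ccc(C(F)(F)F)cc1)NNC(=S)NCCCCC1CCCCC1` gives 540 nM. For compound 2 `O=C(COc1ccccc1)NNC(=S)NCCCCC1CCCCC1` only a limit is reported, > 100000 nM. For compound 3 likewise only a limit is reported, > 100000 nM. Compound 3 therefore sits at the limit of > 100000 nM in this assay, at which 2 of the 3 values shown sit, and has no number of its own. The unmeasured compound 4 `CC(=O)NNC(=S)NCCCCC1CCCCC1` differs from compound 3 in one place: hydrogen in place of 4-methoxyphenoxy on a saturated chain carbon bound to a carbonyl carbon. The measured steps of an at least 180-fold higher number from compound 1 to compound 2 (2.26 log units; beyond the scatter) and an at least 180-fold higher number from compound 1 to compound 3 (2.26 log units; beyond the scatter) concern only the group on the aromatic ring, and a step that the two limits leave unreadable from compound 2 to compound 3 cannot be read; none of them covers loss of the whole 4-methoxyphenoxy. Compound 4 is expected to stay at the limit, estimated at 200000 nM between 50000 nM and 1000000 nM. The step that the limit leaves unreadable from compound 3 to compound 4 that this estimate means is thus not expected to be readable.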

Compound 4, half-maximal inhibitory concentration: > 100000 nM
Compound 4 was reported as a limit; the forecaster's own chance of this, stated with the estimate: 85%; the middle value is on the limit's open side.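

Compound 4 gives only a limit, as compound 2 and compound 3 do, so no step among these three can be read in this assay: the limit of > 100000 nM in this assay, at which 3 of the 4 values shown sit. Going by these compounds, whether these three compounds differ at all stays open.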